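The source may hold more compounds than are shown below. What is called first, only, known or untested is meant among the compounds shown, and "the series" means these compounds.

For the measured compounds named here, compound 2 `COc1ccc(C(=O)/C=C/c2cc(-c3cc(OC)c(OC)c(OC)c3)n[nH]2)cc1OC` gives 6000 nM in a functional assay on A498 cells (Homo sapiens) for inhibition, read by sulforhodamine B assay, with a stated time of 48 h (a higher number here means that more compound is tolerated, a lower number that less compound is tolerated), and holds the lowest of the two numbers so far; compound 1 `COc1cc(-c2cc(/C=C/C(=O)c3ccc(N)cc3)[nH]n2)cc(OC)c1OC` gives 13400 nM in this assay. Going by the values given here, the only step measured, a 2.2-fold lower number from compound 1 to compound 2 (0.35 log units; beyond the scatter), changed the same group on the carbonyl carbon. Compound 3 `COc1cc(-c2cc(/C=C/C(=O)c3ccc(F)c(F)c3)[nH]n2)cc(OC)c1OC` differs from compound 2 by 3,4-difluorophenyl in place of 3,4-dimethoxyphenyl on a carbonyl carbon. Among the compounds with values here, no measured step exchanges this pair of groups, so the change is expected to be modest, a 1.3-fold higher number from compound 2 to compound 3 (0.12 log units; within the scatter), in this assay. Compound 3 is therefore estimated at 8000 nM, with a range from 3000 nM to 22000 nM.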

Compound 3, concentration lethal to 50% of the cells: > 100000 nM
Compound 3: no number, only a limit; the forecaster's own chance of this, stated with the estimate: 5%; middle value at least 12-fold (1.09 log units) away from the limit.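

In this assay, 3,4-difluorophenyl on a carbonyl carbon gives an at least 16-fold higher number from compound 2 to compound 3 (1.22 log units; beyond the scatter) and an at least 7.4-fold higher number from compound 1 to compound 3 (0.87 log units; beyond the scatter), so this place can carry a far larger change than the modest step seen earlier. Compound 3 gives only a limit, so neither step has an exact size: the limit of > 100000 nM in this assay, at which 1 of the 3 values shown sits. The compounds shown leave open whether both fluorines are needed for this rise, or whether one alone would produce it. They also leave open where a 4-fluorophenyl or a 3,4-dichlorophenyl group on the same carbonyl carbon would fall.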